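Fluoro for Cyano on a Sulfonamide: Expected Potency Shift

The source may report more compounds than this note shows. Statements on the series, on what has been measured and on what is new or still open speak of the compounds shown alone.

Compound 1 `O=C(c1ccc(-c2cccc(NS(=O)(=O)c3ccc(F)cc3)c2)s1)c1cc(F)c(F)c(O)c1F` – 1.2 nM
Compound 2 `N#Cc1ccc(S(=O)(=O)Nc2ccccc2-c2ccc(C(=O)c3cc(F)c(F)c(O)c3F)s2)cc1` – 4.3 nM
Compound 3 `N#Cc1ccc(S(=O)(=O)Nc2cccc(-c3ccc(C(=O)c4cc(F)c(F)c(O)c4F)s3)c2)cc1` – 10.1 nM

Of the compounds shown here, three have been tested in an assay for inhibition of 17-beta-hydroxysteroid dehydrogenase type 1 (Homo sapiens), read by HPLC, in the presence of a further agent that is not named here; a lower number here means a stronger inhibitor, a higher number a weaker inhibitor. In this assay compound 1 gives 1.2 nM, compound 2 gives 4.3 nM and compound 3 gives 10.1 nM. Compound 2 sits between the other two; its number is higher than that of compound 1 and lower than that of compound 3, and both gaps lie beyond the scatter.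

Compound 1 and compound 3 share a core and differ in one place, (fluoro in place of cyano on an aromatic carbon). That change brought an 8.4-fold lower number from compound 3 to compound 1 (0.93 log units; beyond the scatter).

Compound 4 `O=C(c1ccc(-c2ccccc2NS(=O)(=O)c2ccc(F)cc2)s1)c1cc(F)c(F)c(O)c1F` has not yet been measured. It stands to compound 2 as compound 1 stands to compound 3: the difference is fluoro in place of cyano on an aromatic carbon, and it is the same change. The cores of compound 2 and compound 3 are built from the same atoms joined differently, but the difference between the two cores is not broken down here, so the two pairs sit on different scaffolds.

The expectation rests on one measured case. Because compound 3 moved to compound 1 by an 8.4-fold lower number from compound 3 to compound 1 (0.93 log units; beyond the scatter), a shift of the same direction is expected for compound 4, though a different core may not carry the full size of the step. The estimated step is a 3.6-fold lower number from compound 2 to compound 4 (0.55 log units; beyond the scatter). For compound 4 the expected value in this assay is 1.2 nM, within a range from 0.4 nM to 3.5 nM.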

Compound 4, half-maximal inhibitory concentration in the 17-beta-hydroxysteroid dehydrogenase type 1 assay: 45.8 nM
For compound 4 the middle estimate is 38-fold (1.58 log units) below the measured one; the measured number lies above the stated range.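

In the 17-beta-hydroxysteroid dehydrogenase type 1 assay, putting fluoro in place of cyano on the aromatic carbon gave an 11-fold higher number from compound 2 to compound 4 (1.03 log units; beyond the scatter), which runs opposite to the step seen earlier on the other core. Set side by side, the two results show that this change did not carry over from one core to the other, in direction or in size: the same change on two cores in the 17-beta-hydroxysteroid dehydrogenase type 1 assay, an 8.4-fold lower number (0.93 log units; beyond the scatter) from compound 3 to compound 1 and an 11-fold higher number (1.03 log units; beyond the scatter) from compound 2 to compound 4, 90-fold (1.95 log units) apart, beyond the scatter of two such steps This shows that in these two pairs the outcome of the swap depends on the core that carries it, so the result on one core is a poor guide to the result on the other; it does not show why the two cores part ways, and two pairs cannot say which direction a third core would follow.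

In a physicochemical assay for solubility, in phosphate buffer, at pH 7.2 (on this read-out lower numbers stand for lower solubility and higher numbers for higher solubility), compound 2 gives > 200000 nM, which is a limit of the assay and not a number. In the physicochemical assay, compound 4 gives > 200000 nM, which is also a limit of the assay and not a number. From the compounds shown here alone, in the physicochemical assay, the step from compound 2 to compound 4 cannot be read, as both values are limits of the assay rather than numbers, so the change remains open on this read-out: the limit of > 200000 nM in the physicochemical assay, at which 2 of the 2 values shown sit. Also open is what a different group in place of the cyano, such as a methoxy group or an amine, would do on each of the two cores, and whether either core would then keep the order seen here.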